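The compounds below may be only part of what the source reports. "The series", "measured", "known", "first", "only" and "open" are said of these compounds alone.

Compound 3 `COc1cc(-c2nnc3n2NC(c2ccco2)C(C(=O)c2ccc([N+](=O)[O-])cc2)S3)cc(OC)c1OC` belongs to a short series that shares one core and varies only the group on a carbonyl carbon. In a functional assay on PC-3 cells (Homo sapiens) for cytotoxicity, read by MTT assay, with a stated time of 48 h (on this read-out higher numbers stand for weaker inhibition and lower numbers for stronger inhibition), compound 3 gives 27900 nM. Its nearest companion is compound 2 `COc1cc(-c2nnc3n2NC(c2ccco2)C(C(=O)c2ccc(F)cc2)S3)cc(OC)c1OC`, which in this assay gives 27700 nM; the step of a 1.0-fold higher number from compound 2 to compound 3 (0.00 log units; within the scatter) lies within the scatter, so the two cannot be ordered. Compound 1 `COc1cc(-c2nnc3n2NC(c2ccco2)C(C(=O)c2cccs2)S3)cc(OC)c1OC`, carrying thiophen-2-yl on the carbonyl carbon, gives 46200 nM in this assay, and compound 3 sits second highest of the three numbers, with a 1.7-fold lower number from compound 1 to compound 3 (0.22 log units; within the scatter) also within the scatter.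

Compound 4 `COc1cc(-c2nnc3n2NC(c2ccco2)C(C(=O)c2ccco2)S3)cc(OC)c1OC` differs from compound 3 in one place: furan-2-yl in place of 4-nitrophenyl on a carbonyl carbon. For the measured compounds named here, two measured steps bear on this move. Both a 1.7-fold lower number from compound 1 to compound 2 (0.22 log units; within the scatter) and a 1.7-fold lower number from compound 1 to compound 3 (0.22 log units; within the scatter) replaced thiophen-2-yl with a substituted phenyl and stayed within the scatter. The step to compound 4 runs the other way, from a substituted phenyl back to a small heteroaryl group, so on these data no change beyond the scatter is expected in this assay, with compound 1 pointing toward a slightly higher number at most.

For compound 4 the estimate in this assay is 38000 nM, within 18000 nM to 80000 nM, which is the expected step of a 1.4-fold higher number from compound 3 to compound 4 (0.13 log units; within the scatter).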

Compound 4, half-maximal inhibitory concentration: 58300 nM
Estimate against measurement, compound 4: 1.5-fold (0.19 log units) below; the measured number falls inside the stated range.
By their numbers in this assay, from the lowest: compounds 2, 3, 1 and 4 (each within the scatter of the next, the first and the last beyond it).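

For the compounds shown here, on the carbonyl carbon, the swap to furan-2-yl gives the first steps beyond the scatter at this position in this assay: replacing 4-nitrophenyl gives a 2.1-fold higher number from compound 3 to compound 4 (0.32 log units; beyond the scatter), and replacing 4-fluorophenyl gives a 2.1-fold higher number from compound 2 to compound 4 (0.32 log units; beyond the scatter). Going by these compounds alone, both steps are modest, but they show that the group at this position can move the read-out, which no step among the earlier compounds showed. The change does not divide the series cleanly into five-membered and six-membered aromatic rings, and thiophen-2-yl goes against such a division: replacing it with furan-2-yl gives a 1.3-fold higher number from compound 1 to compound 4 (0.10 log units; within the scatter), and compound 1 also stays within the scatter of compound 2 and compound 3.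

Nothing measured here bears on what lies behind these steps. The compounds shown leave open how an unsubstituted phenyl, an aliphatic amine or a carboxylic acid on this carbonyl carbon would read in this assay, and whether any such group would move the number further than the modest steps seen here.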